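Aryl urea series: amino replaces methylsulfanyl, cytotoxicity outlook

The source may hold more compounds than are shown below. What is called first, only, known or untested is meant among the compounds shown, and "the series" means these compounds.

Two members of the series have been run in an ADME assay on Raji cells (Homo sapiens) for cytotoxicity, with a stated time of 72 h; a higher number here means that more compound is needed for the effect, a lower number that less compound is needed. Compound 1 `CSc1ccc(NC(=O)Nc2cc(C)nc3ccccc23)cc1` carries a methylsulfanyl on the phenyl side of the urea. In this assay compound 1 returns > 25000 nM, which is a limit of the assay rather than a number. Compound 2 `Cc1cc(NC(=O)Nc2cccc(C(N)=O)c2)c2ccccc2n1` carries a carboxamide instead. In this assay compound 2 likewise returns > 25000 nM, again a limit and not a number. Compound 1 therefore stands at the limit, with no measured figure to place it against the other value, as both sit at the limit of > 25000 nM in this assay, at which 2 of the 2 values shown sit. Going by the values given here, no step between measured compounds can be counted from this.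

Compound 3 `Cc1cc(NC(=O)Nc2ccc(N)cc2)c2ccccc2n1` is the next candidate for this assay. Its structural change from compound 1 is amino in place of methylsulfanyl on an aromatic carbon.

With both values shown sitting at the limit of > 25000 nM in this assay, at which 2 of the 2 values shown sit, no step beyond the scatter is expected from compound 1 to compound 3, and the estimate is a step that the limit leaves unreadable from compound 1 to compound 3. Compound 3 is expected to give 30000 nM, within a range of 10000 nM to 100000 nM, most likely again reported only as a limit.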

Compound 3, half-maximal effective concentration: > 25000 nM
Compound 3 was reported as a limit; the forecaster's own chance of this, stated with the estimate: 75%; the middle value does not contradict the limit.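

Compound 3 gives > 25000 nM in this assay, which is a limit of the assay and not a number. No step can be read between compound 1 and compound 3, as both stand at the limit: the limit of > 25000 nM in this assay, at which 3 of the 3 values shown sit.

The compounds shown leave open whether amino and methylsulfanyl differ at all in cytotoxicity, since none yields a measured figure.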